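This account rests on a few compounds, and the source may have more. Where it says the series, first, only, none or still open, it means among the compounds named here.

Of the compounds shown here, two in this set have been measured in an assay on microsomes from liver for inhibition of acyl-CoA desaturase 1 (Rattus norvegicus); on this read-out higher numbers stand for weaker inhibition and lower numbers for stronger inhibition. Compound 1, `CCc1ccccc1OC1CCN(c2ccc(-n3ccnc3)nn2)CC1`, gives 4 nM in this assay. Compound 2, `CC(C)(C)c1nnc(-c2ccc(N3CCC(Oc4ccccc4C(F)(F)F)CC3)nn2)o1`, gives 980 nM in this assay. Of these two numbers compound 1 has the lower one, and its gap to compound 2 lies well beyond the usual scatter of repeated measurements, so compound 1 is clearly the stronger inhibitor of the pair. Among the compounds with values here, no two measured compounds differ from each other in a single place, so no single-change step has been observed yet.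

Compound 3, `Cc1ccccc1OC1CCN(c2ccc(-n3ccnc3)nn2)CC1`, has not yet been measured. It differs from compound 1 by one small change: hydrogen in place of methyl on a saturated chain carbon bound to an aromatic carbon. For a change of this kind, no step beyond the scatter is expected in this assay; if anything, a slight drift toward a higher number, meaning weaker inhibition, seems the more likely direction. Compound 3 is therefore expected to give 8 nM in this assay, with a range from 2.5 nM to 30 nM. The estimated step of a 2.0-fold higher number from compound 1 to compound 3 (0.30 log units; within the scatter) is expected to remain within the scatter.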

Compound 3, half-maximal inhibitory concentration: 39 nM
Compound 3: middle estimate off by 4.9-fold (0.69 log units), on the low side, and the stated range ends below it.
By their numbers in this assay, from the lowest: compound 1; then compound 3; then compound 2.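

In this assay the change from ethyl to methyl, which removes a single carbon and leaves the rest of the molecule as it was, brings a 9.8-fold higher number from compound 1 to compound 3 (0.99 log units; beyond the scatter) and so counts as a real difference rather than noise. This shows that the group on the aromatic ring of this pair is not a silent detail: the outer carbon of the ethyl group, on a saturated chain carbon bound to an aromatic carbon, goes with clearly stronger inhibition. Nothing available here accounts for the size of this step, so it stands as an observation without an explanation.

Going by these compounds, with only ethyl and methyl compared at this place, a single step gives a direction for this one pair and no wider pattern, so it remains open whether a longer chain such as propyl, or a branched one such as isopropyl, would give lower or higher numbers than ethyl. Also open, on these data alone, is how a group carrying oxygen, such as methoxy, would compare with ethyl on the core of compound 1.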